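This account rests on a few compounds, and the source may have more. Where it says the series, first, only, none or still open, it means among the compounds named here.

Compound 1 `Oc1ccc(-c2cc(-c3ccco3)cc(-c3cccc(O)c3)n2)cc1`: 1.5%
Compound 2 `Oc1ccc(-c2cc(-c3ccco3)cc(-c3ccc(O)cc3)n2)cc1`: 0%

Among the measured compounds shown here, in an assay on isolated protein for inhibition of DNA topoisomerase 1 (Homo sapiens), with a stated time of 30 min, tested at 20 uM (a higher number here means a stronger effect of the compound at the concentration tested, a lower number a weaker effect), compound 2 gives 0%, and compound 1 gives 1.5%; the one step measured, a number 1.5 percentage points lower from compound 1 to compound 2 (within the scatter), leaves the two within the scatter of each other, so neither can be set apart. Compound 3 `Oc1ccc(-c2cc(-c3ccoc3)cc(-c3ccc(O)cc3)n2)cc1` differs from compound 2 in one place: furan-3-yl in place of furan-2-yl on an aromatic carbon. For the measured compounds named here, no measured step concerns this change, since the only step measured moved a hydroxyphenyl group. With both measured compounds showing essentially no inhibition, the expected step of a number 2 percentage points higher from compound 2 to compound 3 (within the scatter) is none beyond the scatter. Compound 3 is therefore estimated at 2%, within 0% to 12%.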

Compound 3, a percentage reported as inhibition, at one concentration (the size of the read-out at that concentration, not a potency): 0%
For compound 3 the middle estimate is 2 percentage points above the measured one; measured number inside the range.
By their numbers in this assay, from the lowest: compounds 2, 3 and 1 (each within the scatter of the next).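

In this assay, among the compounds shown here, furan-3-yl in place of furan-2-yl gives no change at the digits printed from compound 2 to compound 3 (within the scatter) and so adds the first measured change at this position, opposite the ring nitrogen. Changing how the furan is attached, with the same atoms, does not lift inhibition out of the scatter at the concentration tested. No measurement available explains this result. The compounds shown leave open whether an amine, a carboxylic acid or a longer chain at this position would give measurable inhibition. With so little inhibition across them, they also cannot show which parts of the shared core matter for it.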